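The compounds below may be only part of what the source reports. "The series", "measured", "known", "first", "only" and "open" are said of these compounds alone.

Measured in an assay on cells for inhibition of interleukin-5 receptor subunit alpha (Mus musculus), read by WST assay, with a stated time of 48 h, tested at 30 uM, in the presence of a further agent that is not named here; a higher number here means more inhibition at the concentration tested (going by the name of the read-out), a lower number less inhibition:
compound 1 `CCCC(CO)NCc1nc2c(OCC3CCCCC3)cccc2[nH]1` gives 73.3%
compound 2 `CC(C)(CO)NCc1nc2c(OCC3CCCCC3)cccc2[nH]1` gives 54.7%
compound 3 `COc1ccc(CNCc2nc3c(OCC4CCCCC4)cccc3[nH]2)cc1` gives 43.3%

Compound 3 stands lowest of the three numbers: the steps of a number 30 percentage points lower from compound 1 to compound 3 (beyond the scatter) and a number 11.4 percentage points lower from compound 2 to compound 3 (beyond the scatter) both end at it, and both lie beyond the scatter.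

Compound 4 `COc1ccc(NCc2nc3c(OCC4CCCCC4)cccc3[nH]2)cc1` differs from compound 3 in one place: 4-methoxyphenyl in place of 4-methoxybenzyl on an amine nitrogen. Every measured step exchanges one whole group for another on the amine nitrogen; none takes a group of this kind and removes its chain link to the ring, so they bear only loosely on this change. Their sizes, a number 18.6 percentage points lower from compound 1 to compound 2 (beyond the scatter) and a number 11.4 percentage points lower from compound 2 to compound 3 (beyond the scatter), were all modest. A modest step in this assay is therefore expected for compound 4 as well, with no clear direction. Compound 4 is estimated at 40%, between 20% and 60%, which means an expected step of a number 3.3 percentage points lower from compound 3 to compound 4 (within the scatter).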

Compound 4, a percentage reported as inhibition, at one concentration (the size of the read-out at that concentration, not a potency): 20.3%
Beside the measured number, compound 4's estimate is 19.7 percentage points above it, and the stated range covers the measured number.
By their numbers in this assay, from the lowest: compound 4; then compound 3; then compound 2; then compound 1.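

In this assay the loss of the chain link alone, turning 4-methoxybenzyl on the amine nitrogen into 4-methoxyphenyl, gives a number 23 percentage points lower from compound 3 to compound 4 (beyond the scatter) and so this position responds to a change of only one carbon. Against the two hydroxymethyl groups, 4-methoxyphenyl gives a number 34.4 percentage points lower from compound 2 to compound 4 (beyond the scatter) and a number 53 percentage points lower from compound 1 to compound 4 (beyond the scatter) and compound 4 therefore holds the lowest number of the four, with all its steps beyond the scatter. From the compounds shown here alone, whether a longer chain between the amine nitrogen and the ring would raise the number again, or what a carboxylic acid in place of the methoxy group would do, stays open. Nothing available here explains the drop.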